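This account rests on a few compounds, and the source may have more. Where it says the series, first, only, none or still open, it means among the compounds named here.

Measured compounds in a functional assay on HepG2 cells (Homo sapiens) for antiproliferative activity, read by MTT assay; a lower number here means a stronger inhibitor, a higher number a weaker inhibitor:

compound 1 `O=C(Nc1cccc(CNc2ncnc3ccccc23)c1)Nc1ccccc1F` gives 17500 nM
compound 2 `O=C(Nc1ccc(F)cc1)Nc1cccc(CNc2ncnc3ccccc23)c1` gives 41500 nM
compound 3 `COc1cc2ncnc(NCc3cccc(NC(=O)Nc4ccccc4F)c3)c2cc1OC` gives 24900 nM

Compound 1 and compound 2 share a core and differ in one place: 4-fluorophenyl in place of 2-fluorophenyl on an amide-type nitrogen. That change gives a 2.4-fold higher number from compound 1 to compound 2 (0.38 log units; beyond the scatter). Compound 3 carries the core of compound 3 rather than that of compound 1; the difference between the two cores is not broken down here. What compound 1 and compound 3 show is that their values sit within the scatter of each other, so no order between them is claimed, and the same holds for compound 3 against compound 2.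

Compound 4 `COc1cc2ncnc(NCc3cccc(NC(=O)Nc4ccc(F)cc4)c3)c2cc1OC` is not yet measured. It differs from compound 3 in one place: 4-fluorophenyl in place of 2-fluorophenyl on an amide-type nitrogen. This is the same change as that from compound 1 to compound 2, at the same kind of position, and it is the only instance of the change that has a measured outcome among these compounds. The expectation for compound 4 therefore rests on the step from compound 1 to compound 2, a 2.4-fold higher number from compound 1 to compound 2 (0.38 log units; beyond the scatter), carried over onto compound 3 at 24900 nM. Within the data shown here, whether a change on one core transfers to another is unknown here, since only one pair shows it, so the range is taken wide. Compound 4 is expected to give 55000 nM in this assay, within 25000 nM to 120000 nM. That estimate means a step of a 2.2-fold higher number from compound 3 to compound 4 (0.34 log units; beyond the scatter), which is taken as about the step seen from compound 1 to compound 2.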

Compound 4, half-maximal inhibitory concentration: 36600 nM
Compound 4: the middle estimate sits 1.5-fold (0.18 log units) above what was measured, and the stated range covers the measured number.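

In this assay, putting 4-fluorophenyl in place of 2-fluorophenyl on the amide-type nitrogen of the core of compound 3 gives a 1.5-fold higher number from compound 3 to compound 4 (0.17 log units; within the scatter), so no order between compound 3 and compound 4 is claimed. Set beside the same change on the core of compound 1, this step cannot be told apart from the earlier one: the same change on two cores in this assay, a 2.4-fold higher number (0.38 log units; beyond the scatter) from compound 1 to compound 2 and a 1.5-fold higher number (0.17 log units; within the scatter) from compound 3 to compound 4, 1.6-fold (0.21 log units) apart, within the scatter of two such steps This fits a change that carries over between the two cores, but it does not prove it: only the step on the core of compound 1 stands clear of the scatter, and two pairs can show neither a shared size for the step nor a real difference between the cores.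

The compounds shown carry only 2-fluorophenyl or 4-fluorophenyl on the amide-type nitrogen, which leaves open how an unsubstituted phenyl, a chlorophenyl or a trifluoromethylphenyl would behave there and whether the same change would hold for them. Also open, going by these compounds, is whether the step keeps its size on a third core, for instance one with an amine or a longer alkoxy chain in place of the methoxy groups of compound 3.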